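Swapping a thioether for a benzylamine on a diaminoquinoxaline core

The source may report more compounds than this note shows. Statements on the series, on what has been measured and on what is new or still open speak of the compounds shown alone.

Compound 1, `CCOC(=O)[C@H](CCC(=O)O)NC(=O)c1ccc(Sc2nc3cc(N)cc(N)c3nc2-c2ccccc2)cc1` — 60300 nM
Compound 2, `Nc1cc(N)c2nc(-c3ccccc3)c(Sc3ccc(F)cc3)nc2c1` — 19100 nM
Compound 3, `CCOC(=O)[C@H](CCC(=O)O)NC(=O)c1ccc(Oc2nc3cc(N)cc(N)c3nc2-c2ccccc2)cc1` — 79400 nM

These three compounds were tested in a functional assay on OVCAR-5 cells (Homo sapiens) for inhibition, read by sulforhodamine B assay, with a stated time of 48 h; a lower number here means a stronger inhibitor of growth, a higher number a weaker inhibitor of growth. Compound 2 gives 19100 nM, the lowest number of the three and the strongest inhibitor of growth in this set; compound 1 gives 60300 nM and compound 3 gives 79400 nM, both beyond the scatter from compound 2. Among the measured compounds shown here, none of the measured pairs differs in only one place, so no single step can be read off from them.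

Compound 4, `Nc1cc(N)c2nc(-c3ccccc3)c(NCc3ccc(F)cc3)nc2c1`, has not yet been measured. It is compound 2 with one change: (4-fluorobenzyl)amino in place of (4-fluorophenyl)sulfanyl on an aromatic carbon. For the measured compounds named here, no measured pair here shows what this swap does, so the expectation rests only on the number for compound 2. The step from compound 2 to compound 4 is expected to be small, within or close to the scatter, as a 1.3-fold higher number from compound 2 to compound 4 (0.12 log units; within the scatter). Compound 4 is therefore estimated to give about 25000 nM, with a range from 6000 nM to 100000 nM.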

Compound 4, concentration for 50% growth inhibition: 2630 nM
Compound 4: middle estimate off by 9.5-fold (0.98 log units), on the high side, outside the stated range (below it).
By their numbers in this assay, from the lowest: compound 4; then compound 2; then compounds 1 and 3 (each within the scatter of the next).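

In this assay, the position next to the ring nitrogen and ortho to the phenyl group proves sensitive to what it carries: (4-fluorobenzyl)amino in place of (4-fluorophenyl)sulfanyl gives a 7.3-fold lower number from compound 2 to compound 4 (0.86 log units; beyond the scatter). This single swap alters more than one feature, since sulfur leaves, nitrogen and an extra carbon enter, and the entering group has 1 hydrogen-bond donor where the leaving group has 0. No measurement available here explains the step or shows which of these differences matters.

The compounds shown therefore leave the contributions of the nitrogen and the extra carbon unseparated. A (4-fluorophenyl)amino group would keep the nitrogen without the extra carbon, while a (4-fluorobenzyl)sulfanyl group would keep the extra carbon and the sulfur, so these two groups could pull the effects apart.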